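The compounds below may be only part of what the source reports. "The series", "measured", "known", "first", "only" and "open" are said of these compounds alone.

Measured compounds in the series:

compound 1 `Cc1ccccc1NC(=O)NCC1(c2ccccc2)CCCCC1`; in an assay on microsomes from intestine for inhibition of acyl-CoA:cholesterol acyltransferase (Oryctolagus cuniculus) (on this read-out lower numbers stand for stronger inhibition and higher numbers for weaker inhibition), compound 1 gives 640 nM
compound 2 `CC(C)c1ccccc1NC(=O)NCC1(c2ccccc2)CCCCC1`; compound 2 gives 390 nM
compound 3 `Cc1ccc(NC(=O)NCC2(c3ccccc3)CCCCC2)cc1`; compound 3 gives 4500 nM

Two changes have been measured so far. From compound 1 to compound 2 the change is isopropyl in place of methyl on an aromatic carbon; the step is a 1.6-fold lower number from compound 1 to compound 2 (0.22 log units; within the scatter). From compound 1 to compound 3 the cores differ by 4-methylphenyl in place of 2-methylphenyl on an amide-type nitrogen; the step is a 7.0-fold higher number from compound 1 to compound 3 (0.85 log units; beyond the scatter). Compound 3 thus carries the highest number of the three. For the measured compounds named here, no step is counted between compound 2 and compound 3; their two values simply show compound 2 at the lower number.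

Compound 4 `CC(C)c1ccc(NC(=O)NCC2(c3ccccc3)CCCCC2)cc1` is the next compound for this assay. It differs from compound 3 by isopropyl in place of methyl on an aromatic carbon. Going by the values given here, this is the same kind of change as the one from compound 1 to compound 2, not the same one: in compound 2 the entering group sits ortho to a large group, whereas in compound 4 it sits para to a large group. The change has been seen once among the measured compounds, and that single step was within the scatter. The expectation for compound 4 rests on that one step: a step of similar small size, a 1.5-fold lower number from compound 3 to compound 4 (0.18 log units; within the scatter), is expected from compound 3 to compound 4, with the place differing. Compound 4 is therefore expected to give about 3000 nM in this assay, most likely between 1200 nM and 8000 nM.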

Compound 4, half-maximal inhibitory concentration: 1500 nM
The estimate for compound 4 lay 2.0-fold (0.30 log units) above the measured number; low and high end bracket the measured number.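

In this assay, isopropyl in place of methyl on an aromatic carbon, here para to a large group, gives a 3.0-fold lower number from compound 3 to compound 4 (0.48 log units; beyond the scatter). Set beside the same change on the core of compound 1, the two steps cannot be told apart in size: the same change on two cores in this assay, a 1.6-fold lower number (0.22 log units; within the scatter) from compound 1 to compound 2 and a 3.0-fold lower number (0.48 log units; beyond the scatter) from compound 3 to compound 4, 1.8-fold (0.26 log units) apart, within the scatter of two such steps. The result is consistent with the change carrying over between these two cores with a similar small effect, but it does not show a fixed increment, since the step on the core of compound 1 is within the scatter on its own, the step on the core of compound 3 is beyond it, and the two pairs differ in where the groups sit, so two pairs give no rule for the series and no ground for assigning the effect to any property of isopropyl.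

Still open, on these data alone, is whether the trend from methyl to isopropyl continues with a tert-butyl group or a longer chain such as butyl on the same aromatic carbon. Also open, as far as these compounds go, is how a group of a different kind at that place, such as an amine, a carboxylic acid or a methoxy group, would read in this assay on either core.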